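Opening the chain: a step away from 3-carboxyazetidin-1-yl

A few compounds are considered here, and "the series" means these few. Any claim that something is new, unique, unknown or untested is made for them only; others in the source may bear on it.

Within the data shown here, only three compounds have been measured so far in an ADME assay on a cell-free system (plasma, Homo sapiens); a higher number here means a larger unbound share of the compound, a lower number a smaller unbound share. Compound 1 (`CCc1c(CN2CC(C(=O)O)C2)cccc1-c1nsc(-c2ccc(OC(C)C)c(C(F)(F)F)c2)n1`) gives 0.0026, the middle of the three numbers. Compound 2 (`CCc1c(CN2CC(C(=O)O)C2)cccc1-c1nsc(-c2ccc(CC(C)C)c(C#N)c2)n1`) stands higher at 0.0128, and compound 3 (`CCc1c(CCCC(=O)O)cccc1-c1nsc(-c2cnc(OC(C)C)c(C(F)(F)F)c2)n1`) stands lower at 0.00031. Both gaps to compound 1 are beyond the scatter of repeated measurements.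

Compound 4 (`CCc1c(CCCC(=O)O)cccc1-c1nsc(-c2ccc(OC(C)C)c(C(F)(F)F)c2)n1`) has not been measured yet. It keeps the core of compound 1 and changes one group: 2-carboxyethyl in place of 3-carboxyazetidin-1-yl on a saturated chain carbon bound to an aromatic carbon. Cut one bond further out, (3-carboxyazetidin-1-yl)methyl gives way to 3-carboxypropyl.

Among the measured compounds shown here, no measured pair shows this change on its own, so the size of the step has to be judged indirectly. The best clue is compound 3, which also carries 3-carboxypropyl and has the lowest number at 0.00031. Compound 3 differs from compound 4 elsewhere too, which makes this a loose guide. A downward step beyond the scatter is expected, estimated as a 5.2-fold lower number from compound 1 to compound 4 (0.72 log units; beyond the scatter). For compound 4 the estimated unbound fraction is 0.0005, with an expected range from 0.0002 to 0.0014.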

Compound 4, unbound fraction: 0.00014
Compound 4: middle estimate off by 3.6-fold (0.55 log units), on the high side; the measured number lies below the stated range.
By their numbers in this assay, from the lowest: compound 4; then compound 3; then compound 1; then compound 2.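

In this assay, among these compounds, the change gives a 19-fold lower number from compound 1 to compound 4 (1.27 log units; beyond the scatter), a large step and the first reading of this swap with the rest of the molecule held constant. It shows that the group on a saturated chain carbon bound to an aromatic carbon matters greatly for the unbound share, even though the carboxy group stays in place on both sides of the change: losing the four-membered ring and its nitrogen for the open 2-carboxyethyl chain is enough to move the number strongly downward. Nothing measured here explains why the number falls.

The compounds shown leave open whether the ring or the nitrogen accounts for the step, since the two leave together in this change; an open chain that keeps the nitrogen, or a cyclobutane carboxylic acid that keeps the ring without it, would pull them apart. From the compounds shown here alone, it also remains open whether the step keeps its size with a different group on the far end of the core, such as the isobutyl and nitrile pair of compound 2.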